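This account rests on a few compounds, and the source may have more. Where it says the series, first, only, none or still open, it means among the compounds named here.

Notes on the series. Three compounds sharing one core have numbers in an ADME assay on MT4 cells (Homo sapiens) for cytotoxicity, read by MTT assay; a lower number here means that less compound is tolerated, a higher number that more compound is tolerated. Compound 1 `Cc1cc(C#N)cc(C)c1Oc1ccnc(Nc2ccc(CN3CCCN(S(C)(=O)=O)CC3)cc2)n1` gives 7850 nM. Compound 2 `CCS(=O)(=O)N1CCN(Cc2ccc(Nc3nccc(Oc4c(C)cc(/C=C/C#N)cc4C)n3)cc2)CC1` gives 4600 nM. Compound 3 `Cc1cc(/C=C/C#N)cc(C)c1Oc1ccnc(Nc2ccc(CN3CCCN(S(C)(=O)=O)CC3)cc2)n1` gives 17400 nM, the highest of the three numbers, so it is the compound of which the most is tolerated in this assay. The two measured steps run towards compound 3: a 2.2-fold higher number from compound 1 to compound 3 (0.35 log units; beyond the scatter), and a 3.8-fold higher number from compound 2 to compound 3 (0.58 log units; beyond the scatter).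

Compound 4 `Cc1cc(/C=C/C#N)cc(C)c1Oc1ccnc(Nc2ccc(CN3CCCN(S(=O)(=O)N(C)C)CC3)cc2)n1` is not yet measured. It differs from compound 3 by the following change: dimethylamino in place of methyl on a sulfonyl sulfur

Among the compounds with values here, of the measured steps, only the step from compound 2 to compound 3 touches the sulfonyl end of the molecule, and there the sulfonyl substituent and the ring around the sulfonamide nitrogen changed together, so its size cannot be assigned to the sulfonyl substituent alone; the step from compound 1 to compound 3 sits at the other end of the core and does not bear on this change. Within the data shown here, no measured step isolates a change on the sulfonyl sulfur. The expectation for this assay is therefore a step that is modest at most and may not go beyond the scatter, with the direction uncertain: a 1.2-fold lower number from compound 3 to compound 4 (0.06 log units; within the scatter). Compound 4 is estimated at 15000 nM, with a range from 7000 nM to 35000 nM.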

Compound 4, half-maximal cytotoxic concentration: 3900 nM
Beside the measured number, compound 4's estimate is 3.8-fold (0.59 log units) above it; the whole stated range lies above it.
By their numbers in this assay, from the lowest: compounds 4, 2 and 1 (each within the scatter of the next); then compound 3.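

In this assay, the substituent on the sulfonyl sulfur now has a step of its own: with the ring on the sulfonamide nitrogen and the rest of the molecule held fixed, dimethylamino in place of methyl gives a 4.5-fold lower number from compound 3 to compound 4 (0.65 log units; beyond the scatter), towards less compound being tolerated. Within the data shown here, the earlier step at this end of the molecule, a 3.8-fold higher number from compound 2 to compound 3 (0.58 log units; beyond the scatter), changed the ring and the sulfonyl substituent together, so only this new pair shows that a change on the sulfur alone can move the number beyond the scatter. Nothing measured in these data offers an explanation for the step.

This single pair leaves open whether the step goes with the nitrogen entering on the sulfur or with the larger group, from one heavy atom to three, and methylamino or a longer chain such as propyl on the same sulfur would bear on that question. From the compounds shown here alone, it also remains open whether dimethylamino in place of methyl gives a step of similar size and direction on the cyano core of compound 1 or on the piperazine of compound 2.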